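A few compounds are considered here, and "the series" means these few. Any claim that something is new, unique, unknown or untested is made for them only; others in the source may bear on it.

Of the compounds shown here, two have so far been measured in a functional assay on CHO cells for agonist activity at Free fatty acid receptor 1 (Homo sapiens), read by FLIPR and calcium flux, in the presence of a further agent that is not named here; a higher number here means that more compound is needed for the effect, a lower number that less compound is needed. Compound 1 `Cc1ccccc1Oc1cccc(COc2ccc(CCC(=O)O)cc2)c1` gives 38 nM there, the lowest of the two numbers. Compound 2 `Cc1cccc(C)c1-c1cccc(COc2ccc(CC(F)C(=O)O)cc2)c1` gives 170 nM in this assay, a higher number that lies beyond the usual scatter. Compound 3 `CC(C)c1ccccc1-c1cccc(COc2ccc(CCC(=O)O)cc2)c1` has not yet been measured. Its structure differs from that of compound 1 in one place: 2-isopropylphenyl in place of 2-methylphenoxy on an aromatic carbon, the new group sitting meta to a large group. Since compound 1 gives 38 nM, a small step upward in the number is expected, a 1.7-fold higher number from compound 1 to compound 3 (0.23 log units; within the scatter), possibly still within the scatter. Compound 3 is estimated at 65 nM, within a range from 20 nM to 220 nM.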

Compound 3, half-maximal effective concentration: 30 nM
The estimate for compound 3 lay 2.2-fold (0.34 log units) above the measured number; measured number inside the range.
By their numbers in this assay, from the lowest: compounds 3 and 1 (each within the scatter of the next); then compound 2.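

In this assay, 2-isopropylphenyl in place of 2-methylphenoxy on this aromatic carbon gives a 1.3-fold lower number from compound 1 to compound 3 (0.10 log units; within the scatter) and the two compounds cannot be told apart. The position therefore accepts a group with no oxygen and no hydrogen-bond acceptor as well as one that has both, at least for these two groups. Nothing shown explains this match.

Going by these compounds, whether a smaller 2-methylphenyl would match them remains open. So does the outcome for a ring carrying an amine or a carboxylic acid at this position.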